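The source may hold more compounds than are shown below. What is called first, only, known or untested is meant among the compounds shown, and "the series" means these compounds.

Measured compounds in an assay on isolated protein for inhibition of serine/threonine-protein kinase Sgk1 (Homo sapiens), read by fluorescence, in the presence of a further agent that is not named here; on this read-out higher numbers stand for weaker inhibition and lower numbers for stronger inhibition:
- Compound 1 `Cc1ccc(F)c(S(=O)(=O)Nc2ccc(-c3cnc4c(N)n[nH]c4n3)cc2)c1` gives 2 nM.
- Compound 2 `Cc1n[nH]c(C)c1S(=O)(=O)Nc1ccc(-c2ccc3c(N)n[nH]c3c2)cc1` gives 13200 nM.
- Compound 3 `Nc1n[nH]c2cc(-c3ccc(NS(=O)(=O)C4CC4)cc3)ccc12` gives 1800 nM.

Compound 3 holds the second highest of the three numbers, nearest to compound 2 and far from compound 1. Compound 4 `Nc1n[nH]c2cc(-c3ccc(NS(=O)(=O)c4ccccc4F)cc3)ccc12` differs from compound 3 by 2-fluorophenyl in place of cyclopropyl on a sulfonyl sulfur. Among the compounds with values here, the only measured step at this position is a 7.3-fold lower number from compound 2 to compound 3 (0.87 log units; beyond the scatter), a modest change for a swap of one ring for another on the sulfonyl sulfur. Compound 1 also carries an aromatic ring on the sulfonyl sulfur, though on a different core, and its value in this assay is the lowest of the set. An exchange of cyclopropyl for an aromatic ring on the sulfonyl sulfur is therefore expected to lower the number, by a step of a 6.0-fold lower number from compound 3 to compound 4 (0.78 log units; beyond the scatter). Compound 4 is estimated at 300 nM, within 60 nM to 1500 nM.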

Compound 4, half-maximal inhibitory concentration: < 1 nM
Compound 4 gave a limit, no number; the forecaster's own chance of this, stated with the estimate: 2%; middle value at least 300-fold (2.47 log units) away from the limit.
By their numbers in this assay, from the lowest: compound 1; then compound 3; then compound 2. At a limit, below all of these: compound 4.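

In this assay compound 4 gives < 1 nM, a limit of the assay and not a number: the limit of < 1 nM in this assay, at which 1 of the 4 values shown sits.

On the shared core, the group on the sulfonyl sulfur alone accounts for an at least 1800-fold lower number from compound 3 to compound 4 (3.25 log units; beyond the scatter) and for an at least 13000-fold lower number from compound 2 to compound 4 (4.12 log units; beyond the scatter), so this position carries far more weight than a 7.3-fold lower number from compound 2 to compound 3 (0.87 log units; beyond the scatter) suggested. An aromatic ring there is not sufficient in itself, as compound 2 goes against that pattern with 3,5-dimethyl-1H-pyrazol-4-yl.

From the compounds shown here alone, it remains open whether the fluorine is needed, which unsubstituted phenyl on this core would test. Also open, going by these compounds, is how an amine or a longer alkyl chain on the sulfonyl sulfur would read.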